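Swapping Methoxy for Methylsulfanyl on a Shared Core

This account rests on a few compounds, and the source may have more. Where it says the series, first, only, none or still open, it means among the compounds named here.

Compound 1 `CSc1ccc(Cc2nn(-c3ccccc3)c(=O)c3ccccc23)cc1`, compound 2 `C=CCn1nc(Cc2ccc(SC)cc2)c2ccccc2c1=O` and compound 3 `COc1ccc(Cc2nn(C)c(=O)c3ccccc23)cc1` share one core. In a functional assay on aorta with Alpha-1D adrenergic receptor (Rattus norvegicus) as the target (a lower number here means that less compound is needed, a higher number that more compound is needed for the effect), compound 1 gives only a limit, > 100000 nM. Compound 2 likewise gives only a limit, > 100000 nM. The step that the two limits leave unreadable from compound 1 to compound 2 therefore cannot be read. Compound 3 gives a limit of the other kind, < 100000 nM, which places it apart from the other two on the numbers shown.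

Compound 4 `CSc1ccc(Cc2nn(C)c(=O)c3ccccc23)cc1` differs from compound 3 by methylsulfanyl in place of methoxy on an aromatic carbon. Among the measured compounds shown here, no measured step tests this exchange; the only measured step concerns the aromatic nitrogen and is unreadable. The exchange is expected to give a step that the limit leaves unreadable from compound 3 to compound 4. Compound 4 is estimated at 60000 nM, with a range from 10000 nM to 300000 nM.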

Compound 4, half-maximal effective concentration: 930 nM
Compound 4: middle estimate off by 65-fold (1.81 log units), on the high side, and the stated range ends above it.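

In this assay, the group on the aromatic nitrogen proves decisive while methylsulfanyl stays in place: allyl to methyl is an at least 100-fold lower number from compound 2 to compound 4 (2.03 log units; beyond the scatter), and phenyl to methyl is an at least 100-fold lower number from compound 1 to compound 4 (2.03 log units; beyond the scatter). Among the compounds carrying methylsulfanyl, only the methyl compound gives an actual number rather than a limit. Compound 3 gives only a limit, < 100000 nM, so the exchange of methoxy for methylsulfanyl cannot be read.

Still open, going by these compounds, is how an ethyl group or a bare hydrogen on the aromatic nitrogen would compare with methyl. Also open, on these data alone, is how a chlorine atom or an amine would compare with methylsulfanyl on the aromatic carbon.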